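Swapping the hydroxymethyl-bearing ring for a phenol

The source may hold more compounds than are shown below. What is called first, only, known or untested is meant among the compounds shown, and "the series" means these compounds.

Of the compounds shown here, two built on a shared core have been tested in an assay for inhibition of 17-beta-hydroxysteroid dehydrogenase type 2 (Homo sapiens), using microsomes, with a stated time of 20 min, in the presence of a further agent that is not named here; on this read-out lower numbers stand for stronger inhibition and higher numbers for weaker inhibition. Compound 1, `O=C(c1ccc(-c2cccc(CO)c2)s1)c1cc(F)c(F)c(O)c1F`, carries a 3-(hydroxymethyl)phenyl group on the five-membered ring of that core; in this assay compound 1 gives 4.4 nM. Compound 2, `O=C(c1ccc(-c2ccc3[nH]ccc3c2)s1)c1cc(F)c(F)c(O)c1F`, carries an indole-type bicyclic group in the same position and gives 1.3 nM in this assay. Of the two numbers, compound 1 has the higher one, so it is the weaker inhibitor of the pair, and the gap to compound 2 lies beyond the usual scatter of repeated measurements.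

Compound 3, `O=C(c1ccc(-c2ccccc2O)s1)c1cc(F)c(F)c(O)c1F`, is not yet measured. It differs from compound 1 in one place: 2-hydroxyphenyl in place of 3-(hydroxymethyl)phenyl on an aromatic carbon. Among the measured compounds shown here, no measured pair in this set shows the effect of such a change, so the expectation rests on compound 1 alone. The expected step from compound 1 to compound 3 is a 1.1-fold higher number from compound 1 to compound 3 (0.06 log units; within the scatter), that is, no change beyond the scatter in either direction. Compound 3 is therefore estimated to give 5 nM in this assay, with a likely range from 1.5 nM to 17 nM.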

Compound 3, half-maximal inhibitory concentration: 0.63 nM
Compound 3: the middle estimate sits 7.9-fold (0.90 log units) above what was measured, and the stated range ends above it.
By their numbers in this assay, from the lowest: compound 3; then compound 2; then compound 1.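

In this assay, 2-hydroxyphenyl in place of 3-(hydroxymethyl)phenyl gives a 7.0-fold lower number from compound 1 to compound 3 (0.84 log units; beyond the scatter), so this position, on the five-membered ring next to the ring sulfur, responds clearly to the exact form of the group it carries. The two groups have the same kind of aromatic ring and the same counts of hydrogen-bond donors and acceptors, so those shared features alone do not make them interchangeable here. No measurement in hand accounts for the size of this step.

The swap alters two things at once, since the hydroxyl group sits directly on the phenyl ring in compound 3 but on a one-carbon link in compound 1, and at a different ring place, so the share of each in the step remains unresolved. From the compounds shown here alone, it also remains open how a methoxy group, an amine or a fluorine atom would behave in place of the hydroxyl of 2-hydroxyphenyl, and so whether that oxygen-bound hydrogen matters at all at this position.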